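A few compounds are considered here, and "the series" means these few. Any claim that something is new, unique, unknown or untested is made for them only; others in the source may bear on it.

Working notes on the aryl urea series. Compound 3 `Cc1cc(NC(=O)Nc2ccc(Cl)cc2)c2ccccc2n1` is the reference point for the next step. In an ADME assay on HEK293 cells (Homo sapiens) for cytotoxicity, with a stated time of 72 h (on this read-out lower numbers stand for an effect already at smaller amounts and higher numbers for an effect only at larger amounts of compound), compound 3 gives > 25000 nM, which is a limit of the assay and not a number. Compound 1 `COc1ccc(NC(=O)Nc2cc(C)nc3ccccc23)cc1` is one of the two closest neighbours. In this assay compound 1 gives > 25000 nM, again a limit of the assay. Within the data shown here, compound 2 `COC(=O)c1ccc(NC(=O)Nc2cc(C)nc3ccccc23)cc1` is the only member of the three with a number. In this assay compound 2 gives 15000 nM. The steps among the three are an at least 1.6-fold lower number from compound 1 to compound 2 (0.22 log units; that floor lies within the scatter), an at least 1.6-fold higher number from compound 2 to compound 3 (0.22 log units; that floor lies within the scatter) and a step that the two limits leave unreadable from compound 1 to compound 3; compound 3 thus stands at the limit of > 25000 nM in this assay, at which 2 of the 3 values shown sit, with compound 1 beside it there.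

Compound 4 `Cc1cc(NC(=O)Nc2ccc(C(C)(C)C)cc2)c2ccccc2n1` is the next compound, not yet measured. The change from compound 3 is tert-butyl in place of chloro on an aromatic carbon. The steps measured so far all sit at the same place on the ring, but none of them brings in tert-butyl, and two of the three values are limits, so they bear on the change only loosely. The expectation for compound 4 in this assay is therefore a step that the limit leaves unreadable from compound 3 to compound 4, that is, no step beyond the scatter. Compound 4 is estimated at 30000 nM, within 12000 nM to 80000 nM, with a limit rather than a number the likely outcome.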

Compound 4, half-maximal effective concentration: > 25000 nM
Compound 4: a limit, no number; the forecaster's own chance of this, stated with the estimate: 65%; the middle value lies beyond the limit too.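

Tert-butyl brings 4 heavy atoms where chloro had 1 at this place, para to a large group, and the result in this assay shows that this larger all-carbon group also gives no number. Among these compounds, the one readable step is an at least 1.6-fold higher number from compound 2 to compound 4 (0.22 log units; that floor lies within the scatter), while the steps from compound 1 and from compound 3 to compound 4 cannot be read, as both ends of each are limits. Methoxy, chloro and tert-butyl now share one limit, compound 2 with methoxycarbonyl is the one exception that holds a number, and the floor of its steps to compound 3 and compound 4 stays within the scatter, so the series shows no clear separation at this place: the limit of > 25000 nM in this assay, at which 3 of the 4 values shown sit.

As far as these compounds go, how far compound 1, compound 3 and compound 4 lie beyond the limit, and whether they differ from one another, stays open. Also open, from the compounds shown here alone, is whether an amine or a carboxylic acid at this place, or a change in the shared core, would give a number clearly beyond the scatter from the limit.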